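A few compounds are considered here, and "the series" means these few. Any claim that something is new, unique, unknown or untested is made for them only; others in the source may bear on it.

Measured in a functional assay on MKN-45 cells (Homo sapiens) for inhibition, with a stated time of 72 h; a higher number here means a weaker inhibitor, a lower number a stronger inhibitor:
compound 1 `COc1cc(C(=O)n2ccc3ccccc32)cc(OC)c1OC` gives 5200 nM
compound 2 `COc1cc(C(=O)c2ccc3[nH]ccc3c2)cc(OC)c1OC` gives 88 nM
compound 3 `COc1cc(C(=O)c2ccc3c(ccn3C(C)C)c2)cc(OC)c1OC` gives 470 nM

Compound 2 (at 88 nM) has the lowest number of the three in this assay and is the strongest inhibitor among them. Compound 3 lies nearest to it, and compound 1 lies furthest.

Compound 4 `COc1cc(C(=O)c2ccc3c(ccn3CCC(=O)O)c2)cc(OC)c1OC` has not yet been measured. It differs from compound 2 by one change (2-carboxyethyl in place of hydrogen on an aromatic nitrogen), with 2-carboxyethyl in place of hydrogen on an aromatic nitrogen.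

Among the compounds with values here, only one measured step bears on this nitrogen. Isopropyl in place of hydrogen there gave a 5.3-fold higher number from compound 2 to compound 3 (0.73 log units; beyond the scatter) in this assay. Within the data shown here, no measured compound carries a 2-carboxyethyl group, so this single step is the only guide. A step in the same direction is expected, towards a higher number, and probably somewhat larger.

The estimate corresponds to an expected change (a 20-fold higher number from compound 2 to compound 4 (1.31 log units; beyond the scatter)) that lies beyond the scatter. For compound 4 the expected value is 1800 nM within an estimated range of 350 nM to 9000 nM in this assay.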

Compound 4, half-maximal inhibitory concentration: > 10000 nM
Compound 4: only a limit was reported; the forecaster's own chance of this, stated with the estimate: 15%; at least 5.5-fold (0.74 log units) between middle value and limit.
By their numbers in this assay, from the lowest: compound 2; then compound 3; then compound 1. At a limit, above all of these: compound 4.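

In this assay compound 4 gives only a limit, not a number: the limit of > 10000 nM in this assay, at which 1 of the 4 values shown sits. Substitution on this aromatic nitrogen can therefore cost far more than compound 3 showed, with an at least 110-fold higher number from compound 2 to compound 4 (2.05 log units; beyond the scatter) set against a 5.3-fold higher number from compound 2 to compound 3 (0.73 log units; beyond the scatter) for isopropyl. Exchanging isopropyl for 2-carboxyethyl still gives an at least 21-fold higher number from compound 3 to compound 4 (1.32 log units; beyond the scatter) on the same nitrogen, so the outcome depends on which group enters and not only on the loss of the hydrogen.

On these data alone, how far the true number of compound 4 lies past its limit cannot be read, so the full size of both new steps stays open. Also open, as far as these compounds go, is whether the carboxylic acid or the chain itself accounts for the change, which a methyl ester, a terminal amine or a plain propyl chain on this nitrogen would help to separate.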